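Taking One Bromo Group Off Compound 2

A few compounds are considered here, and "the series" means these few. Any claim that something is new, unique, unknown or untested is made for them only; others in the source may bear on it.

In an ADME assay on HEK293 cells (Homo sapiens) for cytotoxicity, read by reporter gene assay and resazurin assay, with a stated time of 48 h (on this read-out lower numbers stand for higher toxicity in this test and higher numbers for lower toxicity in this test), compound 2 `COc1c(Br)cc(Br)cc1C(=O)Nc1cccc(Cl)c1` reads > 100000 nM, which is a limit and not a number. Compound 3 `COc1c(Br)cccc1C(=O)Nc1cccc(Cl)c1` differs from it by hydrogen in place of bromo on an aromatic carbon, para to a methoxy group. For the measured compounds named here, no measured pair shows this change alone, and the only true number to lean on in this assay is that of compound 1 `O=C(Nc1cccc(Cl)c1)c1cccc(Br)c1` at 51000 nM. A modest move toward higher toxicity is therefore expected, an at least 1.3-fold lower number from compound 2 to compound 3 (0.12 log units; that floor lies within the scatter). Compound 3 is estimated at 75000 nM, with an expected range of 35000 nM to 130000 nM.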

Compound 3, half-maximal cytotoxic concentration: > 100000 nM
Compound 3 gave a limit, no number; the forecaster's own chance of this, stated with the estimate: 40%; middle value at least 1.3-fold (0.12 log units) away from the limit.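

The step from bromo to hydrogen at this position cannot be read in this assay, because both compounds stop at the same limit: the limit of > 100000 nM in this assay, at which 2 of the 3 values shown sit. What is new is that the compound with hydrogen here also stays at that limit, so with the methoxy group present, the reading does not depend on this bromo group. Against compound 1, the added methoxy group gives an at least 1.9-fold higher number from compound 1 to compound 3 (0.29 log units; that floor lies within the scatter), so this step does not yet clearly separate the two compounds.

Going by these compounds, how far compound 2 and compound 3 lie past the limit stays open. So does whether an amine or a carboxylic acid at this position would give a true number.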